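A few compounds are considered here, and "the series" means these few. Any claim that something is new, unique, unknown or untested is made for them only; others in the source may bear on it.

Measured so far, all in a functional assay on MCF7 cells (Homo sapiens) for inhibition, read by MTT assay, with a stated time of 72 h; on this read-out higher numbers stand for weaker inhibition and lower numbers for stronger inhibition:
- compound 1 `COc1cc(NC(C)CCCNC(=O)Nc2cccc(F)c2)c2ncccc2c1`: 18000 nM
- compound 2 `COc1cc(NC(C)CCCNC(=O)NNC(=O)Nc2ccc(C(F)(F)F)cc2)c2ncccc2c1`: 100 nM
- compound 3 `COc1cc(NC(C)CCCNC(=O)Nc2cccc(O)c2)c2ncccc2c1`: 11000 nM

Compound 3 (11000 nM) lies within the scatter of compound 1 (18000 nM), and compound 2 (100 nM) has a number far lower than either, well beyond the scatter.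

Next is compound 4 `COc1cc(NC(C)CCCNC(=O)NNC(=O)Nc2cccc(F)c2)c2ncccc2c1`, which takes ((3-fluorophenyl)carbamoyl)amino in place of 3-hydroxyphenyl on an amide-type nitrogen. Among the measured compounds shown here, the one measured step, a 1.6-fold lower number from compound 1 to compound 3 (0.21 log units; within the scatter), exchanges fluoro and hydroxy and stays within the scatter, so the ring substituent alone is expected to count for little here. For the measured compounds named here, no measured step isolates the longer unit. Going by the values given here, compound 2 (100 nM) is the only measured compound that carries it, with a trifluoromethyl group on the phenyl ring instead of fluoro, and the effect of that difference is unmeasured. A large step towards a lower number in this assay, meaning stronger inhibition, is therefore expected, ending somewhat short of compound 2. The estimate implies a 22-fold lower number from compound 3 to compound 4 (1.34 log units; beyond the scatter). For compound 4 the estimated value is 500 nM, with an expected range of 120 nM to 2500 nM.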

Compound 4, half-maximal inhibitory concentration: 150 nM
Compound 4: the middle estimate sits 3.3-fold (0.52 log units) above what was measured; low and high end bracket the measured number.
By their numbers in this assay, from the lowest: compounds 2 and 4 (each within the scatter of the next); then compounds 3 and 1 (each within the scatter of the next).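

On the amide-type nitrogen, ((3-fluorophenyl)carbamoyl)amino in place of 3-fluorophenyl gives a 120-fold lower number from compound 1 to compound 4 (2.08 log units; beyond the scatter) in this assay and so isolates the longer unit, with the phenyl ring and its fluoro kept; in place of 3-hydroxyphenyl the same unit gives a 73-fold lower number from compound 3 to compound 4 (1.87 log units; beyond the scatter) on the same read-out. With the longer unit held constant, 3-fluorophenyl in place of 4-(trifluoromethyl)phenyl gives a 1.5-fold higher number from compound 2 to compound 4 (0.18 log units; within the scatter) and stays within the scatter, so across these two compounds the change of ring substituent does not move the number the way the longer unit does. Nothing measured here gives a reason for the size of these steps.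

Still open, on these data alone, is which part of the longer unit carries the step, and whether it would hold with a methyl or a cyclohexyl group at the end of the unit in place of the phenyl ring. Also open, as far as these compounds go, is how far the ring tolerates other substituents under the longer unit, such as a carboxylic acid or a dimethylamino group, and whether a longer chain to the shared core keeps the number near that of compound 4 in this assay on this read-out.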